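The compounds below may be only part of what the source reports. "The series", "measured", "known", "first", "only" and "open" are said of these compounds alone.

Compound 3 `O=C(CCl)Nc1ccc(C(=O)/C=C/c2ccc(Cl)cc2)cc1` gives 4960 nM in a functional assay on MGC-803 cells (Homo sapiens) for cytotoxicity, read by MTT assay, with a stated time of 72 h (a lower number here means a stronger inhibitor, a higher number a weaker inhibitor), the lowest number among the three measured compounds. The other two share a different core: compound 1 `O=C(CSC(=S)N[C@H]1CCOC1=O)Nc1ccc(Cl)cc1` gives 76900 nM in this assay, and compound 2 `O=C(CSC(=S)N[C@H]1CCOC1=O)Nc1ccc(Cl)cc1Cl` gives 48500 nM. How the core of compound 3 differs from that of compound 2 is not broken down here.

Within the shared core of compounds 1 and 2, the change hydrogen in place of chloro on an aromatic carbon made the step of a 1.6-fold higher number from compound 2 to compound 1 (0.20 log units; within the scatter). The same kind of change, (hydrogen in place of chloro on an aromatic carbon), turns compound 3 into compound 4 `O=C(CCl)Nc1ccc(C(=O)/C=C/c2ccccc2)cc1`. The surroundings differ: in compound 2 the chloro sits ortho to a large group and meta to a chloro group, whereas in compound 3 it sits para to a large group, and the cores themselves differ.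

On the strength of the earlier step from compound 2 to compound 1, the step from compound 3 to compound 4 is expected to be a 1.7-fold higher number from compound 3 to compound 4 (0.23 log units; within the scatter), modest and close to the scatter. Compound 4 is thus estimated at 8500 nM in this assay, plausibly between 3000 nM and 25000 nM.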

Compound 4, half-maximal inhibitory concentration: 6940 nM
Compound 4: middle estimate off by 1.2-fold (0.09 log units), on the high side; measured number inside the range.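

In this assay the change of 4-chlorophenyl to phenyl gives a 1.4-fold higher number from compound 3 to compound 4 (0.15 log units; within the scatter), so on this core the loss of the chloro does not move the number beyond the scatter. Set beside the earlier step, the same change reads alike on the two cores: the same change on two cores in this assay, a 1.6-fold higher number (0.20 log units; within the scatter) from compound 2 to compound 1 and a 1.4-fold higher number (0.15 log units; within the scatter) from compound 3 to compound 4, 1.1-fold (0.05 log units) apart, within the scatter of two such steps. This shows that the step stayed within the scatter in both settings, but each reading rests on a single pair in one assay, so it does not show a real shared effect of the chloro, nor that the agreement would hold on a further core or at another place on the ring.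

The compounds shown leave open whether a methoxy group or an amine, para to a large group on the same ring, would move the number beyond the scatter. They also leave open what would follow if an amine replaced the remaining chloro of compound 4.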